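Stereoisomers of a fluorinated quaternary ammonium on ileum

The source may hold more compounds than are shown below. What is called first, only, known or untested is meant among the compounds shown, and "the series" means these compounds.

Measured so far:
compound 1, `C[C@H]1O[C@@H](C[N+](C)(C)C)CC1(F)F`, a functional assay on ileum with muscarinic acetylcholine receptor M3 (Cavia porcellus) as the target; a lower number here means a smaller maximal response, a higher number a larger maximal response: 0.98
compound 2, `C[C@@H]1O[C@@H](C[N+](C)(C)C)CC1(F)F`, this assay: 0.97

Compound 2 and compound 1 stand within the scatter of each other; compound 2 gives a number no different from compound 1 beyond repeat variation. Within the data shown here, the only measured step, a number 0.010 lower from compound 1 to compound 2 (within the scatter), rests on the fact that compounds 1 and 2 differ only in the configuration as drawn and shows that inverting one stereocentre at a saturated ring carbon leaves the maximal response unchanged.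

Compound 3, `C[C@H]1O[C@H](C[N+](C)(C)C)CC1(F)F`, is not yet measured. Its change from compound 2 is the two compounds have the same atoms and bonds and differ only in configuration as drawn: 2 of 2 stereo elements differ (all stereocentres are inverted: mirror images); a stereocentre at a saturated ring carbon is drawn S in compound 2 and R in compound 3; a stereocentre at a saturated ring carbon is drawn R in compound 2 and S in compound 3. Among the measured compounds shown here, the measured step bears on it only in part: it covers one inverted stereocentre, whereas here both are inverted; no step between mirror images is known. On that basis no step beyond the scatter is expected, a number 0.020 lower from compound 2 to compound 3 (within the scatter). Compound 3 is estimated at 0.95, between 0.8 and 1.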

Compound 3, intrinsic activity: the largest response reached, as a fraction of the reference agonist's: 0.99
The estimate for compound 3 lay 0.040 below the measured number, and the stated range covers the measured number.
By their numbers in this assay, from the lowest: compounds 2, 1 and 3 (each within the scatter of the next).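

Mirror images now have a measured step in this assay (a number 0.020 higher from compound 2 to compound 3 (within the scatter)), so inverting both stereocentres leaves the maximal response as unchanged as inverting one. The other stereocentre, untested until now, has its own single inversion (a number 0.010 higher from compound 1 to compound 3 (within the scatter)), and this step also lies within the scatter. Each stereocentre has therefore been inverted alone, and both together, without a step beyond the scatter, so among compounds 1, 2 and 3 the maximal response does not separate the configurations.

Maximal response alone leaves open whether these stereoisomers differ in the concentration needed to reach it. Also open, going by these compounds, is whether the response holds when a tertiary amine stands in place of the quaternary ammonium, or when a longer chain such as ethyl stands in place of the methyl.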